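Cyclohexyl to 4-methylphenyl on the ring amide nitrogen

The compounds below may be only part of what the source reports. "The series", "measured", "known", "first", "only" and "open" are said of these compounds alone.

- Compound 1 `O=C1COc2ccc(-c3cccc(NS(=O)(=O)c4ccc(F)cc4)c3)cc2N1c1ccccc1`: > 40000 nM (a limit)
- Compound 2 `O=C1COc2ccc(-c3cccc(NS(=O)(=O)c4ccc(F)cc4)c3)cc2N1C1CCCCC1`: 14500 nM

Within the data shown here, in a functional assay on A549 cells (Homo sapiens) for antiproliferative activity, read by MTT assay, with a stated time of 72 h (a lower number here means a stronger inhibitor, a higher number a weaker inhibitor), compound 2 gives 14500 nM, the only actual number so far. Compound 1 stands at > 40000 nM, which is a limit. Compound 3 `Cc1ccc(N2C(=O)COc3ccc(-c4cccc(NS(=O)(=O)c5ccc(F)cc5)c4)cc32)cc1` differs from compound 2 by 4-methylphenyl in place of cyclohexyl on an amide-type nitrogen in a ring. Among the measured compounds shown here, the one measured step bearing on this is an at least 2.7-fold lower number from compound 1 to compound 2 (0.44 log units; beyond the scatter), with cyclohexyl replacing phenyl on the same nitrogen. The new change runs the opposite way, back to a phenyl ring that now carries a methyl group, so a step of similar size towards a higher number is expected in this assay. The expected step is a 2.4-fold higher number from compound 2 to compound 3 (0.38 log units; beyond the scatter). For compound 3 the estimate is 35000 nM, with an expected range of 15000 nM to 70000 nM. A report of only a limit would not be surprising.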

Compound 3, half-maximal inhibitory concentration: > 40000 nM
Compound 3: a limit, no number; the forecaster's own chance of this, stated with the estimate: 55%; at least 1.1-fold (0.05 log units) between middle value and limit.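

In this assay, the change to 4-methylphenyl gives an at least 2.7-fold higher number from compound 2 to compound 3 (0.44 log units; beyond the scatter), so the lower number with cyclohexyl now holds against a second aromatic group on this nitrogen, not only against phenyl. The step between compound 1 and compound 3 cannot be read, as both values are limits, and the added methyl group therefore has no readable effect here. Compound 2 remains the only compound with an actual number, and both compounds with an aromatic ring on this nitrogen end in a limit: the limit of > 40000 nM in this assay, at which 2 of the 3 values shown sit.

On these data alone, how far the aromatic compounds actually lie from compound 2 remains open. Also open, as far as these compounds go, is whether a cyclopentyl ring, a longer chain such as n-butyl or a dimethylaminoethyl chain on this nitrogen would keep or improve on compound 2, at 14500 nM.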